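The compounds below may be only part of what the source reports. "The series", "measured", "known", "first", "only" and "open" are said of these compounds alone.

Measured compounds in an assay on isolated protein for inhibition of DNA topoisomerase 1 (Homo sapiens), with a stated time of 30 min, tested at 100 uM; on this read-out lower numbers stand for a weaker effect and higher numbers for a stronger effect at the one concentration tested:

- compound 1 `Oc1ccc(-c2cc(-c3cccc(Cl)c3)nc(-c3ccccn3)c2)cc1` gives 59.4%
- compound 2 `Oc1ccc(-c2cc(-c3cccs3)nc(-c3ccccc3Cl)c2)cc1` gives 2.2%
- compound 3 `Oc1cccc(-c2cc(-c3ccccn3)nc(-c3ccccc3Cl)c2)c1` gives 0%

Compound 3 stands lowest of the three numbers in this assay. Its nearest neighbour is compound 2, whose number lies within the scatter of that of compound 3, so the two cannot be told apart on these data. The furthest is compound 1, whose number lies beyond the scatter above compound 3; compound 1 differs from compound 3 in more than one place, so no single cause can be read from that gap.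

Compound 4 `Oc1ccc(-c2cc(-c3ccccn3)nc(-c3ccccc3Cl)c2)cc1` is not yet measured. It differs from compound 3 in one place: 4-hydroxyphenyl in place of 3-hydroxyphenyl on an aromatic carbon. For the measured compounds named here, no pair of measured compounds differs in only this place, so the size of this step has no direct precedent. Compound 1 and compound 2 both carry the 4-hydroxyphenyl group and give widely separated numbers, so that group alone settles little. Compound 4 is expected to move upward from compound 3 by a modest step, a number 15 percentage points higher from compound 3 to compound 4 (beyond the scatter), with the possibility that the change stays within the scatter. Compound 4 is therefore estimated at 15%, in the range 0% to 45%.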

Compound 4, a percentage reported as inhibition, at one concentration (the size of the read-out at that concentration, not a potency): 5.2%
For compound 4 the middle estimate is 9.8 percentage points above the measured one; measured number inside the range.
By their numbers in this assay, from the lowest: compounds 3, 2 and 4 (each within the scatter of the next); then compound 1.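

Working notes: in this assay, 4-hydroxyphenyl in place of 3-hydroxyphenyl, on the carbon opposite the ring nitrogen, gives a number 5.2 percentage points higher from compound 3 to compound 4 (within the scatter), so with 2-chlorophenyl present this change cannot be told from no change. Pyridin-2-yl in place of thiophen-2-yl gives a number 3 percentage points higher from compound 2 to compound 4 (within the scatter), so that change cannot be told from no change either. For the compounds shown here, by contrast, 2-chlorophenyl in place of 3-chlorophenyl gives a number 54.2 percentage points lower from compound 1 to compound 4 (beyond the scatter), the only step here beyond the scatter, which places the large difference at the chlorophenyl group rather than at the hydroxyphenyl position.

No measurement here bears on why the chlorine position matters so much. Still open, on these data alone, is whether the hydroxyphenyl change stays this small with 3-chlorophenyl in the molecule, and whether an amine or a carboxylic acid in place of the hydroxyl would register at all.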